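The source may report more compounds than this note shows. Statements on the series, on what has been measured and on what is new or still open speak of the compounds shown alone.

Measured in a functional assay on ZR-75-1 cells (Homo sapiens) for inhibition, read by sulforhodamine B assay; a lower number here means a stronger inhibitor of growth, a higher number a weaker inhibitor of growth:
- compound 1 `COc1cc(-c2ccc(-c3ccc(-c4nc5cc(C)ccc5[nH]4)cc3)cc2)cc(OC)c1OC`: 190 nM
- compound 2 `COc1cc(-c2ccc(-c3ccc(-c4nc5ccccc5[nH]4)cc3)cc2)cc(OC)c1OC`: 9710 nM
- compound 3 `COc1ccc(-c2ccc(-c3ccc(-c4nc5c(O)cccc5[nH]4)cc3)cc2)cc1OC`: 2110 nM

Among these three, compound 3 at 2110 nM holds the middle place. Its number is lower than that of compound 2 at 9710 nM and higher than that of compound 1 at 190 nM.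

Compound 4 `COc1cc(-c2ccc(-c3ccc(-c4nc5c(O)cccc5[nH]4)cc3)cc2)cc(OC)c1OC` has not yet been measured. It comes from compound 3 by one change, methoxy in place of hydrogen on an aromatic carbon, ortho to a methoxy group: methoxy in place of hydrogen on an aromatic carbon.

Within the data shown here, no measured step makes this same change. The only one available, a 51-fold higher number from compound 1 to compound 2 (1.71 log units; beyond the scatter), is hydrogen in place of methyl on an aromatic carbon, in a different ring. It is large and lies beyond the scatter, so a single small change can matter greatly in this set, but it gives no direction for the methoxy change. Compound 4 shares its methoxy pattern with compound 1 and compound 2, whose values lie far apart, so the range must stay wide.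

With no direction to go on, the expected change is modest, and the estimated step is a 1.4-fold lower number from compound 3 to compound 4 (0.15 log units; within the scatter). For compound 4 the estimated value in this assay is 1500 nM, with an expected range of 250 nM to 8000 nM.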

Compound 4, concentration for 50% growth inhibition: 190 nM
Compound 4: middle estimate off by 7.9-fold (0.90 log units), on the high side; the whole stated range lies above it.
By their numbers in this assay, from the lowest: compounds 1 and 4 (each within the scatter of the next); then compound 3; then compound 2.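

In this assay, among these compounds, a methoxy in place of hydrogen on an aromatic carbon, ortho to a methoxy group, gives an 11-fold lower number from compound 3 to compound 4 (1.05 log units; beyond the scatter) and is therefore no minor edit: this one position on the methoxy-bearing ring carries a large step, which the earlier compounds could not show. With that methoxy pattern in place, the gain of a hydroxy group gives a 51-fold lower number from compound 2 to compound 4 (1.71 log units; beyond the scatter) in the same assay, so a large step at the other end of the molecule is not tied to the methyl group of compound 1 alone. A direct swap of the two end groups, 4-hydroxy-1H-benzimidazol-2-yl in place of 5-methyl-1H-benzimidazol-2-yl, gives no change at the digits printed from compound 1 to compound 4 (within the scatter) and leaves the two indistinguishable in this assay, although they differ in both the group and its place.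

On these data alone, whether an ethoxy or an amine at the new methoxy position would give a step of similar size remains open, as does the effect of a carboxylic acid in place of the hydroxy. Nothing at hand explains why any of these steps has the size it does.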